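The compounds below may be only part of what the source reports. "The series", "measured", "known", "first", "only" and "open" are said of these compounds alone.

In an ADME assay on microsomes from liver (Mus musculus) for metabolic stability (on this read-out lower numbers stand for slow clearance and higher numbers for fast clearance), compound 1 `CCn1nc(CC(=O)Nc2ccc(OC(F)(F)F)c(Cl)c2)c2ccccc2c1=O` gives 81.7 mL/min/kg and compound 3 `CC(C(=O)O)c1nn(Cc2cn3cc(OCC4CC4)c(Cl)cc3n2)c2ccccc2c1=O` gives 80 mL/min/kg, so compound 3 stands within the scatter of compound 1. Compound 2 `O=C(O)Cn1nc(Cc2nc3cc(Cl)c(OCC(F)F)cc3[nH]2)c2ccccc2c1=O` gives < 56.7 mL/min/kg, which is a limit of the assay and not a number. Compound 4 `O=C(O)Cc1nn(Cc2cn3cc(OCC4CC4)c(Cl)cc3n2)c2ccccc2c1=O` differs from compound 3 by hydrogen in place of methyl on a saturated chain carbon bound to an aromatic carbon and a carbonyl carbon, which reads as 1-carboxyethyl to carboxymethyl. Among the compounds with values here, no measured pair shows this change, and no shift beyond the scatter is expected in this assay. The estimated step is a 1.2-fold lower number from compound 3 to compound 4 (0.09 log units; within the scatter). Compound 4 is expected to give 65 mL/min/kg, with an estimated range from 45 mL/min/kg to 90 mL/min/kg.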

Compound 4, clearance: < 51.7 mL/min/kg
Compound 4: only a limit was reported; the forecaster's own chance of this, stated with the estimate: 35%; middle value at least 1.2-fold (0.09 log units) from the limit.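

Within the data shown here, replacing methyl with hydrogen on the saturated chain carbon bound to an aromatic carbon and a carbonyl carbon, which turns 1-carboxyethyl into carboxymethyl, gives the only step that can be read in this assay: it is an at least 1.5-fold lower number from compound 3 to compound 4 (0.18 log units; that floor lies within the scatter). That floor alone does not show a shift beyond the scatter. The full size of the step stays unknown because compound 4 carries a limit and not a number: the limit of < 51.7 mL/min/kg in this assay, at which 1 of the 4 values shown sits.

The compounds shown leave open how an ethyl on this carbon, or a tetrazole in place of the carboxylic acid, would read in this assay.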